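This account rests on a few compounds, and the source may have more. Where it says the series, first, only, none or still open, it means among the compounds named here.

Working notes on the series. Compound 3 `N#CCCCN(Cc1ccccc1)Cc1ccc2ccccc2c1` in an assay on HEK293 cells for binding affinity to Substance-K receptor (Rattus norvegicus), read by FRET, tested at 10 uM (a higher number here means more inhibition at the concentration tested (going by the name of the read-out), a lower number less inhibition), gives 0%; compound 1 `N#CCN(Cc1ccccc1)Cc1ccc2ccccc2c1` gives 0% and compound 2 `C#CCN(Cc1ccccc1)Cc1ccc2ccccc2c1` gives 0%, so compound 3 stands level with both at the digits shown. The steps of no change at the digits printed from compound 1 to compound 2 (within the scatter), no change at the digits printed from compound 1 to compound 3 (within the scatter) and no change at the digits printed from compound 2 to compound 3 (within the scatter) are all within the scatter; the whole set is flat.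

Compound 4 `CCOC(=O)CCCCN(Cc1ccccc1)Cc1ccc2ccccc2c1` is not yet measured. It differs from compound 3 as follows: (ethoxycarbonyl)methyl in place of cyano on a saturated chain carbon, three bonds along the chain from an amine nitrogen. Going by the values given here, no measured step exchanges a nitrile for an ester, so none bears directly on this change; the nearest comparisons, varying the chain on the same nitrogen, all read as no change.

The step from compound 3 to compound 4 is therefore expected to be none beyond the scatter, a number 2 percentage points higher from compound 3 to compound 4 (within the scatter). Compound 4 is estimated at 2%, within -8% to 15%.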

Compound 4, a percentage reported as inhibition, at one concentration (the size of the read-out at that concentration, not a potency): 0%
The estimate for compound 4 lay 2 percentage points above the measured number; the measured number falls inside the stated range.
By their numbers in this assay, from the lowest: compounds 1, 2, 3 and 4 (each within the scatter of the next).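

In this assay, going by these compounds alone, the exchange of cyano for (ethoxycarbonyl)methyl gives no change at the digits printed from compound 3 to compound 4 (within the scatter) and so extends the flat set from nitrile and alkyne chain ends to an ester, the first carbonyl group at this position. The longer comparisons agree, with no change at the digits printed from compound 2 to compound 4 (within the scatter) and no change at the digits printed from compound 1 to compound 4 (within the scatter) as the readings for 3-(ethoxycarbonyl)propyl in place of ethynyl and of cyano. No evidence is available to explain this flat result.

Going by these compounds, whether a carboxylic acid or an amine at the chain end would give any inhibition remains open. The same holds for changes to the shared core.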